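Trifluoromethyl in Place of Chloro on the Aromatic Ring

The source may hold more compounds than are shown below. What is called first, only, known or untested is meant among the compounds shown, and "the series" means these compounds.

Compound 1, `CSc1ccc(C)cc1NCC1=NCCN1`, gives 0.912 nM in a functional assay for agonist activity at Alpha-1D adrenergic receptor (Homo sapiens); on this read-out higher numbers stand for an effect only at larger amounts of compound and lower numbers for an effect already at smaller amounts.
Compound 2, `COc1ccc(SC)c(NCC2=NCCN2)c1`, gives 5.01 nM in this assay.
Compound 3, `CSc1ccc(Cl)cc1NCC1=NCCN1`, gives 2.69 nM in this assay.

Compound 3 stands second highest of the three numbers: the nearest is a 1.9-fold lower number from compound 2 to compound 3 (0.27 log units; within the scatter), the furthest a 2.9-fold higher number from compound 1 to compound 3 (0.47 log units; beyond the scatter). Compound 4, `CSc1ccc(C(F)(F)F)cc1NCC1=NCCN1`, differs from compound 3 by trifluoromethyl in place of chloro on an aromatic carbon. Going by the values given here, no measured step exchanges trifluoromethyl for chloro, so only the two changes at the same aromatic carbon offer guidance, and both were modest: a 2.9-fold higher number from compound 1 to compound 3 (0.47 log units; beyond the scatter) and a 1.9-fold lower number from compound 2 to compound 3 (0.27 log units; within the scatter). A comparably small step is therefore expected, a 1.7-fold higher number from compound 3 to compound 4 (0.22 log units; within the scatter), quite possibly within the scatter. Compound 4 is expected to give 4.5 nM, in a range from 1.5 nM to 14 nM.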

Compound 4, half-maximal effective concentration: 43.7 nM
For compound 4 the middle estimate is 9.7-fold (0.99 log units) below the measured one; measured number above the stated range.
By their numbers in this assay, from the lowest: compound 1; then compounds 3 and 2 (each within the scatter of the next); then compound 4.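

With trifluoromethyl on this aromatic carbon, para to a methylsulfanyl group, an effect needs clearly more compound than with any of the three earlier groups: a 16-fold higher number from compound 3 to compound 4 (1.21 log units; beyond the scatter), an 8.7-fold higher number from compound 2 to compound 4 (0.94 log units; beyond the scatter) and a 48-fold higher number from compound 1 to compound 4 (1.68 log units; beyond the scatter). The earlier compounds shown here showed only smaller shifts among methyl, methoxy and chloro, so they gave no sign that one exchange here could matter this much.

Nothing available explains the loss. Going by these compounds, whether a single fluorine, a nitrile or an ethyl group at this carbon would behave like chloro or like trifluoromethyl remains open.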